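The source may report more compounds than this note shows. Statements on the series, on what has been measured and on what is new or still open speak of the compounds shown alone.

Of the compounds shown here, three of one series have been measured in a functional assay on CCRF-CEM cells (Homo sapiens) for cytotoxicity, read by sulforhodamine B assay, with a stated time of 48 h, tested at 1 uM; on this read-out higher numbers stand for a weaker effect at the one concentration tested and lower numbers for a stronger effect. Compound 1, `COc1ccc(-c2cc(/C=C/C(=O)c3ccc(OC)c(OC)c3)[nH]n2)cc1`, gives 63%. Compound 3, `COc1ccc(-c2cc(/C=C/C(=O)c3cc(OC)c(OC)c(OC)c3)[nH]n2)cc1OC`, gives 14%. Compound 2, `COc1cc(-c2cc(/C=C/C(=O)c3ccc(Cl)c(Cl)c3)[nH]n2)cc(OC)c1OC`, gives 71%, the highest of the three numbers; its gap to compound 1 lies within the scatter, whereas its gap to compound 3 lies beyond it. Compound 4, `COc1cc(-c2cc(/C=C/C(=O)c3ccc(F)c(F)c3)[nH]n2)cc(OC)c1OC`, has not yet been measured. It differs from compound 2 in one place: 3,4-difluorophenyl in place of 3,4-dichlorophenyl on a carbonyl carbon. Among the compounds with values here, no pair of measured compounds shows what such an exchange of one halogen pair for another does, so nothing can be read off directly. The step expected in this assay, a number 1 percentage points lower from compound 2 to compound 4 (within the scatter), is none beyond the scatter. Compound 4 is thus expected to give about 70%, within a range from 50% to 90%.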

Compound 4, a percentage reported as activity, at one concentration (the size of the read-out at that concentration, not a potency): 91%
Compound 4: the middle estimate sits 21 percentage points below what was measured; measured number outside the range, above it.
By their numbers in this assay, from the lowest: compound 3; then compounds 1 and 2 (each within the scatter of the next); then compound 4.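

Exchanging one halogen pair for the other on this carbonyl carbon matters: in this assay the change to 3,4-difluorophenyl gives a number 20 percentage points higher from compound 2 to compound 4 (beyond the scatter) and thus a weaker effect at the one concentration tested. This position therefore responds to which halogen the phenyl ring carries, although both groups count the same heavy atoms. Nothing measured here explains this step. On these data alone, whether an amine or a carboxylic acid on this phenyl ring would give a stronger effect stays open. So does whether the same exchange would give a similar step in other members of the series.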